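Swapping Chloro for Methylsulfanyl: Expected Mitochondrial Inhibition

A few compounds are considered here, and "the series" means these few. Any claim that something is new, unique, unknown or untested is made for them only; others in the source may bear on it.

Of the compounds shown here, two have been tested in a toxicity assay on mitochondria from liver (Rattus norvegicus) for inhibition, tested at 100 uM, in the presence of a further agent that is not named here; on this read-out lower numbers stand for less inhibition and higher numbers for more inhibition at the one concentration tested (going by the name of the read-out). Compound 1, with the structure `N#Cc1cc(C(=O)N2CCc3ccccc32)ccc1O`, gives 43% in this assay. Compound 2, with the structure `N#Cc1cc(C(=O)N2CS(=O)(=O)c3ccccc32)cc(Cl)c1O`, gives 20% in this assay. Of these two numbers compound 2 stands lowest; the nearest is compound 1, whose number is higher by an amount beyond the usual scatter of such measurements. The two structures differ in more than one place, so that gap cannot be tied to any single change.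

Compound 3, with the structure `CSc1cc(C(=O)N2CS(=O)(=O)c3ccccc32)cc(C#N)c1O`, has not yet been measured in this assay. It differs from compound 2 in one place: methylsulfanyl in place of chloro on an aromatic carbon. Both the part that leaves and the part that enters carry no ring and no net charge. For the measured compounds named here, nothing among the measured compounds shows what this swap does in this assay, so the expectation rests on compound 2 alone. The expected step in this assay is a number 5 percentage points higher from compound 2 to compound 3 (within the scatter), which means no movement beyond the scatter. For compound 3 the estimated value in this assay is therefore 25%, with a range from 8% to 45%.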

Compound 3, a percentage reported as inhibition, at one concentration (the size of the read-out at that concentration, not a potency): 21%
Compound 3: the middle estimate sits 4 percentage points above what was measured; low and high end bracket the measured number.
By their numbers in this assay, from the lowest: compounds 2 and 3 (each within the scatter of the next); then compound 1.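

In this assay the swap on this aromatic carbon, ortho to a hydroxy group and meta to a cyano group, comes out as a number 1 percentage points higher from compound 2 to compound 3 (within the scatter) and so shows no movement beyond the scatter. For the compounds shown here, this is the first comparison that changes only one place, and it shows that this position accepts methylsulfanyl, with 2 heavy atoms and 1 hydrogen-bond acceptor, in place of chloro, with 1 heavy atom and 0 hydrogen-bond acceptors, with no visible change in the read-out at the one concentration tested. Nothing available explains why the read-out holds steady across this change.

Chloro and methylsulfanyl are the only two groups seen at this position, so it remains open whether an amine, a carboxylic acid or a longer chain such as butylsulfanyl would leave the read-out equally unmoved. As far as these compounds go, it also remains open which of the several structural differences between compound 1 and the other two compounds matters in this assay for this assay, and whether this swap would behave the same way on the core of compound 1.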